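A few compounds are considered here, and "the series" means these few. Any claim that something is new, unique, unknown or untested is made for them only; others in the source may bear on it.

Working notes on the series. Of the compounds shown here, two sharing one core have been measured in a functional assay on RPMI-8226 cells (Homo sapiens) for inhibition, read by sulforhodamine B assay, tested at 10 uM; a higher number here means more inhibition at the concentration tested (going by the name of the read-out), a lower number less inhibition. Compound 1 `COc1cc2oc(-c3cccc(C(=O)Nc4ccc(Cl)cc4)c3)cc(=O)c2c(OC)c1OC` gives 82.6%. Compound 2 `COc1cc2oc(-c3cccc(C(=O)Nc4ccc(C)cc4)c3)cc(=O)c2c(O)c1OC` gives 82.6%. The two values stand level at the digits shown, so compound 2 sits where compound 1 sits, with no difference beyond the scatter, though the two structures differ in more than one place and no single step can be drawn between them.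

Compound 3 `COc1cc2oc(-c3cccc(C(=O)Nc4ccc(Cl)cc4)c3)cc(=O)c2c(O)c1OC` has not yet been measured in this assay. It differs from compound 2 in one place only: chloro in place of methyl on an aromatic carbon. The same chloro group is present in compound 1, and compound 1 and compound 2 both give the same reading, so no step beyond the scatter is expected from compound 2 to compound 3 in either direction.

Compound 3 is therefore estimated at 82%, within 70% to 92%, the expected step being a number 0.6 percentage points lower from compound 2 to compound 3 (within the scatter).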

Compound 3, a percentage reported as inhibition, at one concentration (the size of the read-out at that concentration, not a potency): 82.6%
Beside the measured number, compound 3's estimate is 0.6 percentage points below it, and the stated range covers the measured number.
By their numbers in this assay, from the lowest: compounds 1, 2 and 3 (each within the scatter of the next).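

In this assay, the change from 4-methylphenyl to 4-chlorophenyl can now be read on its own as no change at the digits printed from compound 2 to compound 3 (within the scatter), so at this position, para to a large group, chloro and methyl cannot be told apart, with compound 3 at 82.6%. The second single change, hydrogen in place of methyl on an oxygen on an aromatic ring, reads no change at the digits printed from compound 1 to compound 3 (within the scatter), so the level shared by compound 1 and compound 2 now resolves into two separate changes, neither showing a step beyond the scatter. No available data bear on why these readings coincide.

On these data alone, all three readings come from one concentration, so whether the compounds would separate at lower concentrations stays open. Also open, as far as these compounds go, is whether an amine, a carboxylic acid or a longer chain at this position would hold the same level.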